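Cyclohexyl for Propyl on the Aromatic Nitrogen

A few compounds are considered here, and "the series" means these few. Any claim that something is new, unique, unknown or untested is made for them only; others in the source may bear on it.

Compound 2, `CCCn1nc(C)c2c1NC(=O)CN=C2c1ccccc1Cl`, is measured in a functional assay on the whole organism (strain Holtzman) with Rattus norvegicus as the target (a lower number here means that less compound is needed, a higher number that more compound is needed for the effect), where compound 2 gives 40 mg/kg. Compound 1, `CCc1nn(C)c2c1C(c1ccc(F)cc1)=NCC(=O)N2C`, reaches only a limit in this assay, at > 40 mg/kg. Compound 3, `CCCCn1nc(C)c2c1NC(=O)CN=C2c1cccc(Cl)c1`, likewise reaches only a limit, at > 40 mg/kg. Compound 2 thus stands as the only numeric value among the three shown; the other two sit at the limit of > 40 mg/kg in this assay, at which 2 of the 3 values shown sit. Within the data shown here, no step between two measured compounds that differ in one place is available, so no measured change can guide the next step.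

Compound 4, `Cc1nn(C2CCCCC2)c2c1C(c1ccccc1Cl)=NCC(=O)N2`, differs from compound 2 by cyclohexyl in place of propyl on an aromatic nitrogen. The change is from propyl to cyclohexyl on an aromatic nitrogen. With nothing measured to set the direction, the step from compound 2 to compound 4 in this assay is expected to be none beyond the usual scatter, no change at the digits printed from compound 2 to compound 4 (within the scatter), and there is a real chance that only a limit is reported. Compound 4 is accordingly estimated at 40 mg/kg, with a range from 15 mg/kg to 120 mg/kg.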

Compound 4, minimum effective dose: > 40 mg/kg
Compound 4 was reported as a limit (the forecaster's own chance of this, stated with the estimate: 45%); the middle value lies on the limit itself.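

Among these compounds, this is the first step at this position that can be read: in this assay, cyclohexyl in place of propyl on the aromatic nitrogen gives a number no lower from compound 2 to compound 4 (the limit leaves the size open). Compound 4 gives > 40 mg/kg, which is a limit of the assay and not a number. Compound 2 therefore remains the only one of the four compounds with a numeric value, and the exchange of the propyl chain for the six-carbon ring brought no reading of a lower dose, with the values now gathered at one point: the limit of > 40 mg/kg in this assay, at which 3 of the 4 values shown sit.

On these data alone, how far compound 4 lies past its limit stays open, so the size of the step is unknown. Also open, as far as these compounds go, is whether a benzyl group or an aminoethyl chain on this nitrogen would give a numeric value in this assay.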